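The source may report more compounds than this note shows. Statements on the series, on what has been measured and on what is new or still open speak of the compounds shown alone.

Within the data shown here, compound 3 `COc1ccc(CN2C(=O)C(=O)c3cc(-c4ccc(Cl)cc4)ccc32)cc1` gives the lowest number of the three values so far in a functional assay on HepG2 cells (Homo sapiens) for antiproliferative activity, read by MTT assay, with a stated time of 48 h (on this read-out higher numbers stand for weaker inhibition and lower numbers for stronger inhibition), with 380 nM. Among the measured compounds shown here, the nearest is compound 2 `COc1ccc(CN2C(=O)C(=O)c3cc(-c4cc(OC)cc(OC)c4)ccc32)cc1`, which in this assay gives 1200 nM; the one measured step, a 3.2-fold lower number from compound 2 to compound 3 (0.50 log units; beyond the scatter), is a modest change. Furthest away is compound 1 `O=C1Nc2ccc(-c3ccc(C(F)(F)F)cc3)cc2C1=O`, which in this assay gives 5430 nM; it differs from compound 3 in more than one place, so no single step connects the two, and the gap is only what the two values show.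

Compound 4 `COc1ccc(CN2C(=O)C(=O)c3cc(-c4ccc(C(F)(F)F)cc4)ccc32)cc1` follows from compound 3 by one change: trifluoromethyl in place of chloro on an aromatic carbon. For the measured compounds named here, no measured step exchanges these two groups, so the only guidance is indirect. The step from compound 2 to compound 3 concerns a different part of the same aryl ring and does not bear on it directly, while compound 1 shares the trifluoromethyl group but lacks the rest of compound 3. Nothing here argues for a change beyond the scatter in either direction. Compound 4 is therefore expected to come out close to compound 3, with the step of a 1.3-fold higher number from compound 3 to compound 4 (0.12 log units; within the scatter) as the estimate, giving an expected value of 500 nM for compound 4, within a range from 150 nM to 1600 nM.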

Compound 4, half-maximal inhibitory concentration: 820 nM
Beside the measured number, compound 4's estimate is 1.6-fold (0.21 log units) below it; low and high end bracket the measured number.
By their numbers in this assay, from the lowest: compound 3; then compounds 4 and 2 (each within the scatter of the next); then compound 1.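

Trifluoromethyl and chloro are not interchangeable at this aromatic carbon in this assay: a 2.2-fold higher number from compound 3 to compound 4 (0.33 log units; beyond the scatter) is a modest step, and it is the first reading of any exchange at this position that keeps the ring otherwise unchanged. The comparison with the other aryl group gives a different result, for a 1.5-fold lower number from compound 2 to compound 4 (0.17 log units; within the scatter) leaves 4-(trifluoromethyl)phenyl and 3,5-dimethoxyphenyl unresolved, so among these three groups only 4-chlorophenyl stands apart from both others. Among these compounds, compound 4 also provides the first single-place reading at the ring nitrogen, where 4-methoxybenzyl in place of hydrogen gives a 6.6-fold lower number from compound 1 to compound 4 (0.82 log units; beyond the scatter) with the 4-(trifluoromethyl)phenyl group held constant, a modest step in the same direction as a lower number.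

As far as these compounds go, it remains open how a fluoro, bromo or nitrile group would read at this aromatic carbon, and whether the nitrogen step would hold with 4-chlorophenyl in place or with a plain benzyl or ethyl group on the nitrogen. Nothing available accounts for the size of these steps, so they stand only as measured differences.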